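The source may hold more compounds than are shown below. What is called first, only, known or untested is meant among the compounds shown, and "the series" means these compounds.

Compound 2 `Nc1nc(-c2ccco2)nc2sc(CN3CCCC3)cc12` gives 6430 nM in an assay on CHO-K1 cells for antagonist activity at adenosine receptor A1 (Homo sapiens), read by a beta-galactosidase reporter, with stated times of 15 min and 6 h (on this read-out higher numbers stand for weaker inhibition and lower numbers for stronger inhibition), the highest of the three numbers shown. Compound 1 `Nc1nc(-c2ccco2)nc2sc(CNC3CCCCC3)cc12` gives 2480 nM in this assay, and compound 3 `Nc1nc(-c2ccco2)nc2sc(CN3CCC(F)CC3)cc12` gives 740 nM. The measured steps all concern the amine on the saturated chain carbon: a 2.6-fold higher number from compound 1 to compound 2 (0.41 log units; beyond the scatter), a 3.4-fold lower number from compound 1 to compound 3 (0.53 log units; beyond the scatter) and an 8.7-fold lower number from compound 2 to compound 3 (0.94 log units; beyond the scatter). Compound 4 `Nc1nc(-c2ccc(Br)o2)nc2sc(CN3CCCC3)cc12` keeps the amine of compound 2 and differs from it only by bromo in place of hydrogen on an aromatic carbon, on the furan-2-yl that all three measured compounds share unchanged. None of the measured steps therefore bears on this change, and the shown data give no size or direction for it. With nothing to go on beyond the shared scaffold, the number for compound 4 is expected to stay close to that of compound 2, with no step beyond the scatter, as in a 1.3-fold lower number from compound 2 to compound 4 (0.11 log units; within the scatter). For compound 4 the estimate in this assay is 5000 nM, with a range from 1500 nM to 16000 nM.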

Compound 4, inhibition constant: 710 nM
Compound 4: middle estimate off by 7.0-fold (0.85 log units), on the high side; the whole stated range lies above it.
By their numbers in this assay, from the lowest: compounds 4 and 3 (each within the scatter of the next); then compound 1; then compound 2.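

Among these compounds, the furan-2-yl, constant across the earlier compounds, proves able to move the number in this assay: bromo in place of hydrogen on an aromatic carbon gives a 9.1-fold lower number from compound 2 to compound 4 (0.96 log units; beyond the scatter). This one-atom change next to the ring oxygen is about as large as the amine exchange that gives an 8.7-fold lower number from compound 2 to compound 3 (0.94 log units; beyond the scatter), so the furan carries as much weight here as the amine did in that step. Nothing shown gives a reason for this step.

From the compounds shown here alone, whether chloro, methyl or a nitrile at this place would move the number in the same direction remains open. It is also open whether bromo would have a similar effect alongside the cyclohexylamino of compound 1 or the 4-fluoropiperidin-1-yl of compound 3, since the only step shown for it has the pyrrolidin-1-yl amine.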